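Methylsulfanyl for methoxy on the fused ring of compound 2

A few compounds are considered here, and "the series" means these few. Any claim that something is new, unique, unknown or untested is made for them only; others in the source may bear on it.

Among the compounds with values here, compound 2 `COc1cc(OC)n2s/c(=N\C(=O)c3c(-c4ccc(Cl)cc4Cl)noc3C)nc2n1` gives 85.6% in a functional assay on the whole organism (strain L.) for inhibition, with Echinochloa crus-galli as the target, with a stated time of 72 h, tested at 100 mg/L (a lower number here means less inhibition of growth, a higher number more inhibition of growth at the concentration tested), the higher of the two numbers known so far; compound 1 `CSc1cc(C)nc(NC(=S)NC(=O)c2c(-c3ccc(Cl)cc3Cl)noc2C)n1` gives 47.1% in this assay, a gap beyond the scatter. Compound 3 `COc1cc(SC)nc2n/c(=N/C(=O)c3c(-c4ccc(Cl)cc4Cl)noc3C)sn12` carries the change (methylsulfanyl in place of methoxy on an aromatic carbon), on an aromatic carbon of a six-membered aromatic ring with 2 nitrogen, next to the ring nitrogen. Within the data shown here, no measured pair shows this exchange, so the direction is open; a small step is expected, none beyond the scatter. The expected value for compound 3 is 80%, within a range from 60% to 95%. The step of a number 5.6 percentage points lower from compound 2 to compound 3 (within the scatter) is thus estimated to stay within the scatter.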

Compound 3, percent growth inhibition at one concentration: 55.6%
Compound 3: middle estimate off by 24.4 percentage points, on the high side; the whole stated range lies above it.
By their numbers in this assay, from the lowest: compounds 1 and 3 (each within the scatter of the next); then compound 2.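

In this assay, methylsulfanyl in place of methoxy gives a number 30 percentage points lower from compound 2 to compound 3 (beyond the scatter). This position, on an aromatic carbon next to the ring nitrogen, therefore responds to an exchange of oxygen for sulfur, although the heavy-atom and hydrogen-bond acceptor counts stay the same. Nothing measured here bears on the reason for this step.

From the compounds shown here alone, whether the drop follows sulfur specifically or any replacement of methoxy at this carbon stays open; an amine or an ethoxy group there would help separate the two. This single pair also leaves open whether the remaining methoxy group responds in the same way.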